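This account rests on a few compounds, and the source may have more. Where it says the series, first, only, none or still open, it means among the compounds named here.

In a functional assay on the whole organism with Mus musculus as the target (on this read-out higher numbers stand for an effect only at larger amounts of compound and lower numbers for an effect already at smaller amounts), compound 1 `Cc1c(C)c2c(c(C)c1N)CC(C)(C)O2` gives 7.8 mg/kg, compound 2 `Cc1c(C)c2c(c(C)c1N)CC(C)(CSc1ccccc1)O2` gives 24.7 mg/kg and compound 3 `Cc1c(C)c2c(c(C)c1N)CC(C)(CSCCC(=O)O)O2` gives 43 mg/kg. Compound 3 stands clear of compound 1, with a 5.5-fold higher number from compound 1 to compound 3 (0.74 log units; beyond the scatter), a modest step beyond the scatter. Against compound 2 it shows a 1.7-fold higher number from compound 2 to compound 3 (0.24 log units; within the scatter), which lies within the scatter, so these two cannot be told apart.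

The next compound, compound 4 `Cc1c(C)c2c(c(C)c1N)CC(C)(CN1CCCCC1)O2`, has not yet been measured. Its difference from compound 3 is piperidin-1-yl in place of (2-carboxyethyl)sulfanyl on a saturated chain carbon bound to a saturated ring carbon. Thus piperidin-1-yl stands in place of (2-carboxyethyl)sulfanyl on a saturated chain carbon bound to a saturated ring carbon.

Within the data shown here, two measured steps concern this same place: a 3.2-fold higher number from compound 1 to compound 2 (0.50 log units; beyond the scatter) and the step to compound 3 already given, both modest. The exchange on the sulfur, from phenyl to 2-carboxyethyl, stayed within the scatter. Among the measured compounds shown here, no measured compound carries piperidin-1-yl, so the data offer only an indirect guide. A replacement at this place is therefore expected to leave the number near those of compound 2 and compound 3, or somewhat nearer that of compound 1.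

The expected change is small, a 2.0-fold lower number from compound 3 to compound 4 (0.29 log units; within the scatter), leaning towards a lower number without clearly passing the scatter. For compound 4 the estimate is 22 mg/kg, with an expected range from 8 mg/kg to 60 mg/kg.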

Compound 4, dose for 50% inhibition: 11.7 mg/kg
Compound 4: the middle estimate sits 1.9-fold (0.27 log units) above what was measured; the measured number falls inside the stated range.
By their numbers in this assay, from the lowest: compounds 1 and 4 (each within the scatter of the next); then compounds 2 and 3 (each within the scatter of the next).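

In this assay, a substituent at this place, on a saturated chain carbon bound to a saturated ring carbon, need not shift the number: with piperidin-1-yl there is a 1.5-fold higher number from compound 1 to compound 4 (0.18 log units; within the scatter), so compound 1 and compound 4 cannot be told apart, whereas both sulfanyl groups had given numbers beyond the scatter from compound 1. The exchange on the sulfur had suggested little sensitivity to the entering group, but a 3.7-fold lower number from compound 3 to compound 4 (0.57 log units; beyond the scatter) and a 2.1-fold lower number from compound 2 to compound 4 (0.32 log units; beyond the scatter) show that the group at this place does matter, even though compound 2 and compound 3 themselves could not be told apart. Piperidin-1-yl and (2-carboxyethyl)sulfanyl have the same count of heavy atoms, so that count alone does not follow the number here, and no further data at hand account for the gap.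

Going by these compounds, whether the ring nitrogen or the ring as a whole goes with the lower number remains open, and a cyclohexyl, morpholin-4-yl or diethylamino group at this place would help to separate the two. Also open, on these data alone, is whether the sulfur atom itself goes with the higher numbers, which a carboxylic acid chain joined through nitrogen or carbon instead would address.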